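What swapping a carbonyl may do in compound 4

The compounds below may be only part of what the source reports. "The series", "measured", "known", "first", "only" and "open" are said of these compounds alone.

In a physicochemical assay for solubility, read by chemiluminescence, measured as kinetic solubility (a higher number here means a more soluble compound, a lower number a less soluble compound), compound 1 `Clc1ccc(CNc2ccnc(N3CCC4(CCN(CC5CCCN5)C4)CC3)n2)c(Cl)c1` gives 270 ug/mL and compound 2 `Fc1ccc(CNc2ccnc(N3CCC4(CCN(CC5CCCN5)C4)CC3)n2)c(F)c1` gives 160 ug/mL. Among the measured compounds shown here, the one measured step between them, a 1.7-fold lower number from compound 1 to compound 2 (0.23 log units; within the scatter), stays within the scatter. Compound 3 `CN(Cc1ccc(Cl)cc1Cl)c1ccnc(N2CCC3(CCN(C(=O)C4CCCN4)C3)CC2)n1` gives 190 ug/mL, which lies within the scatter of both others, so it holds no clear rank among them.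

Compound 4 `CN(Cc1ccc(Cl)cc1Cl)c1ccnc(N2CCC3(CCN(CC4CCCN4)C3)CC2)n1` differs from compound 3 in one place: (pyrrolidin-2-yl)methyl in place of (pyrrolidin-2-yl)carbonyl on an amine nitrogen in a ring. The swap sits on an amine nitrogen in a ring. For the measured compounds named here, no measured step makes this swap, and the step above concerns a different part of the molecule. Still, compound 1 and compound 2 already carry (pyrrolidin-2-yl)methyl, and their values sit within the scatter of compound 3, although they differ from it elsewhere too. What is expected in this assay is therefore no change beyond the scatter, an estimated 1.2-fold higher number from compound 3 to compound 4 (0.06 log units; within the scatter). Compound 4 is estimated at 220 ug/mL, with an expected range of 110 ug/mL to 420 ug/mL.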

Compound 4, solubility: 141 ug/mL
Beside the measured number, compound 4's estimate is 1.6-fold (0.19 log units) above it, within the range that was stated.
By their numbers in this assay, from the lowest: compounds 4, 2, 3 and 1 (each within the scatter of the next).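

In this assay, the first direct test at this amine nitrogen in a ring, (pyrrolidin-2-yl)methyl in place of (pyrrolidin-2-yl)carbonyl gives a 1.3-fold lower number from compound 3 to compound 4 (0.13 log units; within the scatter) and so shows no clear effect of losing the carbonyl. The steps from the other two compounds read the same way: (2,4-dichlorobenzyl)(methyl)amino in place of (2,4-difluorobenzyl)amino gives a 1.1-fold lower number from compound 2 to compound 4 (0.05 log units; within the scatter) and methyl in place of hydrogen on a nitrogen on an aromatic ring gives a 1.9-fold lower number from compound 1 to compound 4 (0.28 log units; within the scatter) and neither stands out from the scatter. Nothing available here helps to explain these small differences.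

As far as these compounds go, whether a longer chain, such as (pyrrolidin-2-yl)ethyl, or a carboxylic acid on this ring nitrogen would move the number beyond the scatter remains open. So does how the carbonyl version reads with (2,4-difluorobenzyl)amino on the aromatic carbon.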